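This account rests on a few compounds, and the source may have more. Where it says the series, first, only, none or still open, it means among the compounds named here.

Measured so far in an ADME assay on Vero cells (Chlorocebus sabaeus) for cytotoxicity, read by MTT assay, with a stated time of 72 h; a higher number here means that more compound is tolerated, a lower number that less compound is tolerated:
compound 1 `CCOC(=O)CN1CCN(c2c(F)cc3c(=O)c(C(=O)O)cn(C4CC4)c3c2OC)CC1C` — 1000 ug/mL
compound 2 `COc1c(N2CCN(CC(C)=O)C(C)C2)c(F)cc2c(=O)c(C(=O)O)cn(C3CC3)c12` — 500 ug/mL
compound 3 `CO/N=C(\C)CCN1CCN(c2c(F)cc3c(=O)c(C(=O)O)cn(C4CC4)c3c2OC)CC1C` — 157 ug/mL
Not yet measured: compound 4 `COc1c(N2CCN(CC/C(C)=N/NC(N)=O)C(C)C2)c(F)cc2c(=O)c(C(=O)O)cn(C3CC3)c12`.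

Compound 2 stands second highest of the three numbers in this assay: the gap to compound 1, a 2.0-fold lower number from compound 1 to compound 2 (0.30 log units; within the scatter), is within the scatter, while the gap to compound 3, a 3.2-fold lower number from compound 2 to compound 3 (0.50 log units; beyond the scatter), is beyond it. The change to compound 4 is a group of 8 heavy atoms (4 carbon, 3 nitrogen, 1 oxygen; no ring) in place of a group of 3 heavy atoms (2 carbon, 1 oxygen; no ring), on a saturated chain carbon bound to an amine nitrogen in a ring. Among the compounds with values here, the steps that bear on it are a 3.2-fold lower number from compound 2 to compound 3 (0.50 log units; beyond the scatter) and a 6.4-fold lower number from compound 1 to compound 3 (0.80 log units; beyond the scatter), both modest lowerings when a larger group enters on the saturated chain carbon bound to an amine nitrogen in a ring. A lowering of similar size is therefore expected here, a 2.8-fold lower number from compound 2 to compound 4 (0.44 log units; beyond the scatter). Compound 4 is estimated to give 180 ug/mL, in the range 70 ug/mL to 500 ug/mL.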

Compound 4, half-maximal cytotoxic concentration: 31.3 ug/mL
The estimate for compound 4 lay 5.8-fold (0.76 log units) above the measured number, and the stated range ends above it.
By their numbers in this assay, from the lowest: compound 4; then compound 3; then compounds 2 and 1 (each within the scatter of the next).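

In this assay, within the data shown here, this position on a saturated chain carbon bound to an amine nitrogen in a ring can move the number further than the earlier compounds showed: a 16-fold lower number from compound 2 to compound 4 (1.20 log units; beyond the scatter) and a 32-fold lower number from compound 1 to compound 4 (1.50 log units; beyond the scatter) are both large, where earlier steps were modest at most. The end of the chain alone matters, as ureido in place of methoxy on a double-bonded nitrogen gives a 5.0-fold lower number from compound 3 to compound 4 (0.70 log units; beyond the scatter). No measured evidence bears on this result.

On these data alone, whether a plain amine or a carboxylic acid at the end of this chain would stay near compound 2 or fall toward compound 4 remains open. As far as these compounds go, the effect of a longer chain carrying the ureido group is also open.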